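A few compounds are considered here, and "the series" means these few. Any claim that something is new, unique, unknown or untested is made for them only; others in the source may bear on it.

Measured so far in a functional assay on K562 cells (Homo sapiens) for cytotoxicity, read by MTT assay, with a stated time of 48 h; on this read-out lower numbers stand for stronger inhibition and higher numbers for weaker inhibition:

- compound 1 `COc1ccc(CN2C(=O)C(=O)c3cc(/C=C/C(=O)OC(C)(C)C)ccc32)cc1` gives 50 nM
- compound 2 `COC(=O)/C=C/c1cccc2c1N(Cc1ccc(OC)cc1)C(=O)C2=O` gives 4130 nM
- compound 3 `COc1ccc(CN2C(=O)C(=O)c3cc(/C=C/C(=O)OCCO)ccc32)cc1` gives 40 nM

Compound 3 has the lowest of the three numbers in this assay, but its gap to compound 1 is small: a 1.3-fold lower number from compound 1 to compound 3 (0.10 log units; within the scatter), so the two stand together. Compound 2, which carries its ester chain elsewhere on the shared core and differs from compound 3 in more than one place, gives a number far higher than either, beyond the scatter.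

Compound 4 `COC(=O)/C=C/c1ccc2c(c1)C(=O)C(=O)N2Cc1ccc(OC)cc1` is not yet measured. It differs from compound 3 as follows: hydrogen in place of hydroxymethyl on a saturated chain carbon bound to an oxygen next to a carbonyl group

Among the compounds with values here, the only measured step that bears on this change is the one at the same oxygen, from tert-butyl to 2-hydroxyethyl, which stayed within the scatter. Two different groups on that ester oxygen gave practically the same number, so a methyl there is expected to do likewise; no step beyond the scatter is expected, the estimate being a 1.3-fold higher number from compound 3 to compound 4 (0.10 log units; within the scatter).

Compound 4 is therefore expected to give about 50 nM in this assay, within 20 nM to 130 nM.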

Compound 4, half-maximal inhibitory concentration: 3 nM
Estimate against measurement, compound 4: 17-fold (1.22 log units) above, and the stated range ends above it.
By their numbers in this assay, from the lowest: compound 4; then compounds 3 and 1 (each within the scatter of the next); then compound 2.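

The ester oxygen is less indifferent than the earlier pair suggested. In this assay, the methyl ester gives a 13-fold lower number from compound 3 to compound 4 (1.12 log units; beyond the scatter), and against the tert-butyl ester it gives a 17-fold lower number from compound 1 to compound 4 (1.22 log units; beyond the scatter), while the 2-hydroxyethyl and tert-butyl esters stay together at a 1.3-fold lower number from compound 1 to compound 3 (0.10 log units; within the scatter), so among these three esters on the shared core the methyl ester alone stands apart. No measurement at hand accounts for this separation.

Open, on these data alone, is how sharply the number depends on the group at this oxygen: an ethyl or propyl ester would show whether the low number belongs to methyl alone or extends to short unbranched chains. Also open, as far as these compounds go, is whether a free carboxylic acid or a simple amide in place of the methyl ester keeps it.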